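Cytotoxicity notes on a diaryl ether sulfonamide series

A few compounds are considered here, and "the series" means these few. Any claim that something is new, unique, unknown or untested is made for them only; others in the source may bear on it.

Measured compounds:
compound 1 `Cc1cc(S(N)(=O)=O)ccc1NC(=O)COc1ccc(F)cc1Oc1cccc2ccccc12` gives 33100 nM
compound 2 `Cc1cc(S(N)(=O)=O)ccc1NC(=O)COc1ccc(F)cc1Oc1ccc2cc(C#N)ccc2c1Cl` gives 39700 nM

Both compounds were examined in an ADME assay on C8166 cells (Homo sapiens) for cytotoxicity, read by MTT assay; a higher number here means that more compound is tolerated, a lower number that less compound is tolerated. Compound 1 sits alongside compound 2 in this assay; the gap between their two numbers is within the usual scatter, so nothing separates them here.

Compound 3 `Cc1cc(S(N)(=O)=O)ccc1NC(=O)COc1ccc(F)cc1Oc1c(C)cc2ccccc2c1Cl` has not yet been measured in this assay. It differs from compound 1 in one place: 1-chloro-3-methylnaphthalen-2-yl in place of naphthalen-1-yl on an oxygen on an aromatic ring. Compound 2 already carries a chlorine and a nitrile on its naphthyl group and gives a number indistinguishable from compound 1, so the shared core appears to set the tolerated concentration rather than the aryl substituent. The step of a 1.1-fold higher number from compound 1 to compound 3 (0.02 log units; within the scatter) is therefore expected to fall within the scatter, with no clear direction. Compound 3 is estimated to give 35000 nM in this assay, in a range from 15000 nM to 75000 nM.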

Compound 3, half-maximal cytotoxic concentration: 55600 nM
For compound 3 the middle estimate is 1.6-fold (0.20 log units) below the measured one; the measured number falls inside the stated range.
By their numbers in this assay, from the lowest: compounds 1, 2 and 3 (each within the scatter of the next).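

In this assay the change to 1-chloro-3-methylnaphthalen-2-yl in place of naphthalen-1-yl on an oxygen on an aromatic ring gives a 1.7-fold higher number from compound 1 to compound 3 (0.23 log units; within the scatter) and so provides the first step read at this position. The position therefore takes both a different attachment of the naphthyl group and added chlorine and methyl groups, while the number stays within the scatter of that of compound 1. Nothing at hand gives a reason for this result.

Open, as far as these compounds go, is whether a group that is no naphthyl group, such as an amine or a carboxylic acid, would hold the number in the same range at this position. Also open, from the compounds shown here alone, are the separate shares of the chlorine, the methyl and the changed attachment, since this one step carries all three together.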